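Chloro Amide Within a Weakly Active Naphthol Series

This account rests on a few compounds, and the source may have more. Where it says the series, first, only, none or still open, it means among the compounds named here.

Measured compounds:
compound 1 `O=C(Nc1cc(Sc2ncn[nH]2)c(O)c2ccccc12)c1cccc([N+](=O)[O-])c1`: 70200 nM
compound 2 `Cc1nnc(Sc2cc(NC(=O)c3ccc(Cl)cc3)c3ccccc3c2O)s1`: > 100000 nM
compound 3 `O=C(/C=C/c1ccccc1)Nc1cc(Sc2ncn[nH]2)c(O)c2ccccc12`: > 100000 nM

Compound 1 is the only one of the three with a number in a functional assay on HCT-116 cells (Homo sapiens) for antiproliferative activity, read by MTT assay, with a stated time of 48 h (on this read-out higher numbers stand for weaker inhibition and lower numbers for stronger inhibition), where compound 1 gives 70200 nM. Compound 3 gives > 100000 nM in this assay, a limit rather than a number. Compound 2 likewise gives > 100000 nM in this assay, again a limit. For the measured compounds named here, the one measured step into compound 3 is an at least 1.4-fold higher number from compound 1 to compound 3 (0.15 log units; that floor lies within the scatter), and because the limit of > 100000 nM in this assay, at which 2 of the 3 values shown sit, it cannot be sized any further.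

Compound 4 `O=C(Nc1cc(Sc2ncn[nH]2)c(O)c2ccccc12)c1ccc(Cl)cc1` differs from compound 3 by 4-chlorophenyl in place of 2-phenylethenyl on a carbonyl carbon. Compound 2 also carries a 4-chlorophenyl on its carbonyl carbon, though on a different core. Going by the values given here, no measured step directly matches the move from 2-phenylethenyl to 4-chlorophenyl; the only step that bears on the amide substituent, from compound 1 to compound 3, is unsized because of the limit of > 100000 nM in this assay, at which 2 of the 3 values shown sit. Compound 4 is therefore expected to stay close to the limit, with a step of an at least 1.1-fold lower number from compound 3 to compound 4 (0.04 log units; that floor lies within the scatter) that need not be real. The estimate for compound 4 in this assay is 90000 nM, expected to fall between 35000 nM and 200000 nM, with a fair chance that only a limit is reported.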

Compound 4, half-maximal inhibitory concentration: 43300 nM
Beside the measured number, compound 4's estimate is 2.1-fold (0.32 log units) above it, and the stated range covers the measured number.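

With 1H-1,2,4-triazol-5-yl kept on the sulfur, 4-chlorophenyl in place of 2-phenylethenyl on the carbonyl carbon gives an at least 2.3-fold lower number from compound 3 to compound 4 (0.36 log units; beyond the scatter) in this assay, and with 4-chlorophenyl kept on the carbonyl carbon, 1H-1,2,4-triazol-5-yl in place of 5-methyl-1,3,4-thiadiazol-2-yl on the sulfur gives an at least 2.3-fold lower number from compound 2 to compound 4 (0.36 log units; beyond the scatter), so a change at either place can bring a compound off the limit and onto a number. The two aromatic groups on the carbonyl carbon cannot be told apart, with 4-chlorophenyl in place of 3-nitrophenyl giving a 1.6-fold lower number from compound 1 to compound 4 (0.21 log units; within the scatter). The values of compound 2 and compound 3 are limits, and the full size of both steps from them stays unread for that reason: the limit of > 100000 nM in this assay, at which 2 of the 4 values shown sit.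

The compounds shown leave open whether any group on the carbonyl carbon, such as a phenyl ring carrying an amine or a carboxylic acid, or a plain alkyl chain, would give a number far lower than those of compound 1 and compound 4. They also leave open whether the gain at the sulfur holds with other amides, or extends to a second group there, such as an imidazole.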